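Nitro to Trifluoromethyl on Two Related Cores

The compounds below may be only part of what the source reports. "The series", "measured", "known", "first", "only" and "open" are said of these compounds alone.

Three measured compounds share a common core and are compared in a functional assay on A2780 cells (Homo sapiens) for inhibition, with a stated time of 72 h; on this read-out higher numbers stand for weaker inhibition and lower numbers for stronger inhibition. Compound 1 `CN1c2ccc(NC(=O)Nc3ccc([N+](=O)[O-])cc3)cc2C(C)(C)C(O)C1(C)C` gives 8400 nM in this assay. Compound 3 `CN1c2ccc(NC(=O)Nc3ccc(C(F)(F)F)cc3)cc2C(C)(C)C(O)C1(C)C` differs from compound 1 by trifluoromethyl in place of nitro on an aromatic carbon; in this assay compound 3 gives 6700 nM, and the step is a 1.3-fold lower number from compound 1 to compound 3 (0.10 log units; within the scatter). Compound 2 `CN1c2ccc(NC(=S)Nc3ccc([N+](=O)[O-])cc3)cc2C(C)(C)C(O)C1(C)C` gives 10000 nM in this assay, a number within the scatter of both others. The difference between the cores of compound 1 and compound 2 is not broken down here.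

Compound 4 `CN1c2ccc(NC(=S)Nc3ccc(C(F)(F)F)cc3)cc2C(C)(C)C(O)C1(C)C` has not been measured. Among the compounds with values here, it differs from compound 2 by trifluoromethyl in place of nitro on an aromatic carbon, which is the same change, at the same place, as the one from compound 1 to compound 3. Because a 1.3-fold lower number from compound 1 to compound 3 (0.10 log units; within the scatter) lies within the scatter, the expected step is a 1.3-fold lower number from compound 2 to compound 4 (0.10 log units; within the scatter), a small one of the same size. On that basis, compound 4 is estimated to give 8000 nM in this assay, with an expected range from 4000 nM to 16000 nM.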

Compound 4, half-maximal inhibitory concentration: 7600 nM
For compound 4 the middle estimate is 1.1-fold (0.02 log units) above the measured one; the measured number falls inside the stated range.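

In this assay, trifluoromethyl in place of nitro on the aromatic carbon gave a 1.3-fold lower number from compound 2 to compound 4 (0.12 log units; within the scatter), and this step agrees with the one seen earlier on the other core: the same change on two cores in this assay, a 1.3-fold lower number (0.10 log units; within the scatter) from compound 1 to compound 3 and a 1.3-fold lower number (0.12 log units; within the scatter) from compound 2 to compound 4, 1.0-fold (0.02 log units) apart, within the scatter of two such steps. On these two cores, then, the change carried over from one to the other, and neither step lay beyond the scatter. Within the data shown here, this does not show that the change has a real effect on the read-out, since both steps are small enough to be repeat scatter; the agreement shows only that the number stayed about where it was on each core, and two cores cannot speak for the rest of the series.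

The compounds shown leave open whether other groups in the same place, such as an amine, a carboxylic acid or a nitrile, would give a step beyond the scatter on either core. They also leave open whether such a larger step would carry over between the two cores as closely as this small one did.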